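Naphthalen-1-yl in Place of 3-(Trifluoromethyl)phenyl

The source may report more compounds than this note shows. Statements on the series, on what has been measured and on what is new or still open speak of the compounds shown alone.

Measured so far:
compound 1 `Nc1scc(CN2CCN(c3cccc(C(F)(F)F)c3)CC2)c1C(=O)c1ccc(Cl)cc1`: -8.2%
compound 2 `Nc1scc(CN2CCN(c3ccc(C(F)(F)F)cc3)CC2)c1C(=O)c1cccc(C(F)(F)F)c1`: -12%
compound 3 `Nc1scc(CN2CCN(c3c(F)cccc3F)CC2)c1C(=O)c1cccc(C(F)(F)F)c1`: 2.1%

In a functional assay on CHO cells with adenosine receptor A1 (Homo sapiens) as the target, read by cAMP accumulation and immunoassay, with a stated time of 6 min, tested at 0.01 uM (a higher number here means a weaker effect of the compound at the concentration tested, a lower number a stronger effect), compound 1 stands second highest of the three numbers; compound 2 lies within the scatter of it, while compound 3 lies beyond the scatter above it. Compound 4 `Nc1scc(CN2CCN(c3cccc4ccccc34)CC2)c1C(=O)c1ccc(Cl)cc1` is not yet measured; it differs from compound 1 by naphthalen-1-yl in place of 3-(trifluoromethyl)phenyl on an amine nitrogen in a ring. Among the measured compounds shown here, the one measured step that swaps the aromatic group on the same ring nitrogen is a number 14.1 percentage points higher from compound 2 to compound 3 (beyond the scatter), a modest shift. A swap at that position therefore seems able to move the read-out by a modest amount, but the direction of the present swap cannot be read from these three compounds. Compound 4 is expected to give -4%, in the range -20% to 12%, an expected step of a number 4.2 percentage points higher from compound 1 to compound 4 (within the scatter).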

Compound 4, a percentage reported as activity, at one concentration (the size of the read-out at that concentration, not a potency): 8.7%
Estimate against measurement, compound 4: 12.7 percentage points below, within the range that was stated.
By their numbers in this assay, from the lowest: compounds 2 and 1 (each within the scatter of the next); then compounds 3 and 4 (each within the scatter of the next).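

Swapping 3-(trifluoromethyl)phenyl for naphthalen-1-yl gives a number 16.9 percentage points higher from compound 1 to compound 4 (beyond the scatter) in this assay. The aromatic group on this ring nitrogen therefore moves the read-out on the core of compound 1 too, not only on the core shared by compound 2 and compound 3. Here the swap goes with a weaker effect at the single concentration tested, but no measurement at hand explains the shift.

From the compounds shown here alone, whether naphthalen-1-yl behaves the same way on the core of compound 2 remains open. So does the outcome with a pyridine ring or a benzyl group on this nitrogen.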